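The source may hold more compounds than are shown below. What is called first, only, known or untested is meant among the compounds shown, and "the series" means these compounds.

Measured so far in a functional assay on HGC-27 cells (Homo sapiens) for cytotoxicity, read by MTT assay, with a stated time of 72 h; on this read-out lower numbers stand for stronger inhibition and higher numbers for weaker inhibition:

Compound 1 `O=C1C=CCC/C1=C\C=C\c1ccccc1` gives 4500 nM
Compound 2 `O=C1C=CCC/C1=C\C=C\c1ccc([N+](=O)[O-])cc1` gives 5200 nM

Compound 2 gives 5200 nM and stands level with compound 1 on these two numbers. The gap between them lies within the scatter, so neither compound can be ranked ahead of the other.

Compound 3 `CC(=O)Oc1ccc(/C=C/C=C2\CCC=CC2=O)cc1` has not yet been measured. It differs from compound 2 by a single change (acetoxy in place of nitro on an aromatic carbon), acetoxy in place of nitro on an aromatic carbon of the six-membered ring, para to a large group.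

Among the measured compounds shown here, only one measured step bears on this place. That step (a 1.2-fold higher number from compound 1 to compound 2 (0.06 log units; within the scatter)) is nitro in place of hydrogen on an aromatic carbon, and it lies within the scatter. For the measured compounds named here, no compound carrying acetoxy has been measured, so this one small step is thin support for any forecast. On that basis, no step beyond the scatter is expected in this assay for the exchange of nitro for acetoxy. The estimated step (a 1.2-fold lower number from compound 2 to compound 3 (0.06 log units; within the scatter)) therefore stays small. Compound 3 is expected at 4500 nM with an estimated range (2000 nM to 10000 nM).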

Compound 3, half-maximal inhibitory concentration: 4900 nM
Beside the measured number, compound 3's estimate is 1.1-fold (0.04 log units) below it; the measured number falls inside the stated range.
By their numbers in this assay, from the lowest: compounds 1, 3 and 2 (each within the scatter of the next).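

In this assay the acetoxy group gives a 1.1-fold lower number from compound 2 to compound 3 (0.03 log units; within the scatter) when it replaces nitro and a 1.1-fold higher number from compound 1 to compound 3 (0.04 log units; within the scatter) when it replaces hydrogen, so this place on the aromatic ring, para to a large group, has now carried three different substituents with all the numbers level. The earlier compounds shown here showed this for nitro alone, whereas acetoxy is a second group of a different make-up, with carbon and oxygen in place of nitrogen and oxygen and a larger count of heavy atoms, and the read-out still does not separate it from either neighbour. Nothing available on these compounds offers an explanation for this lack of separation.

Nitro and acetoxy have the same counts of hydrogen-bond donors and acceptors, and neither carries a net charge, so the compounds shown leave open whether an amine or a carboxylic acid at this place would also stay level. They also leave open whether a halogen such as chlorine, or a longer chain, would do the same, and whether changes elsewhere on the shared core would move the number at all.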